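A few compounds are considered here, and "the series" means these few. Any claim that something is new, unique, unknown or untested is made for them only; others in the source may bear on it.

Compounds measured in a functional assay on SK-HEP1 cells (Homo sapiens) for cytotoxicity, read by sulforhodamine B assay, with a stated time of 72 h; a lower number here means a stronger inhibitor, a higher number a weaker inhibitor:
compound 1 `CCS(=O)(=O)Nc1cc(-c2ccc3ncnc(Nc4ccc(OC)cc4)c3c2)cnc1OC`: 1610 nM
compound 2 `CCS(=O)(=O)Nc1cc(-c2ccc3ncnc(Nc4ccc(F)c(C(=O)OC)c4)c3c2)cnc1OC`: 5180 nM

Compound 2 stands as the higher of these two numbers, separated from compound 1 by the step of a 3.2-fold higher number from compound 1 to compound 2 (0.51 log units; beyond the scatter). Compound 3 `CCS(=O)(=O)Nc1cc(-c2ccc3ncnc(Nc4ccc(Cl)c(C(=O)OC)c4)c3c2)cnc1OC` differs from compound 2 by chloro in place of fluoro on an aromatic carbon. Going by the values given here, no measured step exchanges one halogen for another; the single step of a 3.2-fold higher number from compound 1 to compound 2 (0.51 log units; beyond the scatter) alters the whole aryl substitution and so bears only loosely on this change. The expected step of a 1.2-fold lower number from compound 2 to compound 3 (0.06 log units; within the scatter) is therefore small, with no clear direction beyond the scatter. Compound 3 is estimated at 4500 nM, within a range of 1800 nM to 11000 nM.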

Compound 3, half-maximal inhibitory concentration: 7060 nM
The estimate for compound 3 lay 1.6-fold (0.20 log units) below the measured number, and the stated range covers the measured number.
By their numbers in this assay, from the lowest: compound 1; then compounds 2 and 3 (each within the scatter of the next).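

In this assay, the exchange on this aromatic carbon, ortho to a methoxycarbonyl group, gives a 1.4-fold higher number from compound 2 to compound 3 (0.13 log units; within the scatter), so fluoro and chloro are not told apart here. The chloro compound also keeps the separation from the 4-methoxyphenyl compound, with a 4.4-fold higher number from compound 1 to compound 3 (0.64 log units; beyond the scatter), so this separation is not confined to the fluoro compound. Going by these compounds alone, no evidence accompanying these compounds bears on this result. The compounds shown leave open how an amine or a bare hydrogen in place of the halogen would read, and how a carboxylic acid in place of the methoxycarbonyl group would read.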